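The source may report more compounds than this note shows. Statements on the series, on what has been measured and on what is new or still open speak of the compounds shown alone.

The series gathers three measured compounds. Compound 1 `O=C(O)[C@@H]1CCCN1C(=O)CN(c1nc(Cl)nc2[nH]cnc12)C1CC1` gives 31.5% in a functional assay on the whole organism (Tail, strain ICR) with Mus musculus as the target, in the tail flick test, with a stated time of 30 min, at a dose of 25 umol/kg by the oral route; on this read-out lower numbers stand for a weaker effect and higher numbers for a stronger effect at the one dose given. Compound 2 `CSCC[C@H](NC(=O)CN(c1ncnc2c1ncn2C1CCCCO1)C1CC1)C(=O)OCc1ccccc1` gives 30% in this assay, and compound 3 `O=C(O)C[C@H](NC(=O)CN(c1nc(Cl)nc2[nH]cnc12)C1CC1)C(=O)O` gives 19.9% in this assay. On these numbers compound 2 stands second highest of the three: its nearest neighbour is compound 1, whose number lies within the scatter of its own, while compound 3 lies furthest from it, lower by a distance beyond the scatter.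

The open question is compound 4 `C[C@@H](O)[C@H](NC(=O)CN(c1ncnc2c1ncn2C1CCCCO1)C1CC1)C(=O)OCc1ccccc1`, which has not been measured in this assay. It differs from compound 2 at one place: 1-hydroxyethyl in place of 2-(methylsulfanyl)ethyl on a saturated chain carbon bound to an amide-type nitrogen and a carbonyl carbon. The group that enters carries one hydrogen-bond donor where the group that leaves carried none. Among the measured compounds shown here, no pair among the measured compounds differs in only one place, so no measured step shows what such a change does here. The expected step is therefore small, not clearly beyond the scatter in either direction, at a number 2 percentage points lower from compound 2 to compound 4 (within the scatter). Compound 4 is estimated at 28%, within a range from 15% to 40%.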

Compound 4, a percentage reported as activity, at one dose (the size of the read-out at that dose, not a potency): 23.6%
Compound 4: the middle estimate sits 4.4 percentage points above what was measured; the range from low to high includes it.
By their numbers in this assay, from the lowest: compounds 3, 4, 2 and 1 (each within the scatter of the next, the first and the last beyond it).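

The series now holds a step in one place: in this assay the result is a number 6.4 percentage points lower from compound 2 to compound 4 (within the scatter) when 1-hydroxyethyl takes the place of 2-(methylsulfanyl)ethyl on a saturated chain carbon bound to an amide-type nitrogen and a carbonyl carbon. At this position, then, losing the sulfur and gaining a hydrogen-bond donor and a defined stereocentre together do not move the read-out beyond the scatter at the one dose given. Nothing measured here explains the size of this step or separates the parts of this exchange.

The compounds shown leave open how an amine, a carboxylic acid or a longer chain would read at this position. They also leave open whether the same exchange would give a step of similar size on a core other than that of compound 2.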